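Swapping Chloro for Trifluoromethoxy on the Aryl Urea

A few compounds are considered here, and "the series" means these few. Any claim that something is new, unique, unknown or untested is made for them only; others in the source may bear on it.

Measured in a functional assay on MDA-MB-436 cells (Homo sapiens) for antiproliferative activity, read by MTT assay, with a stated time of 48 h (on this read-out lower numbers stand for stronger inhibition and higher numbers for weaker inhibition), so far
- compound 1 `COc1ccc(NC(=O)N2CCN(c3ncnc4sc(-c5ccc(N6CCN(C)CC6)cc5)cc34)CC2)cc1` gives 30100 nM
- compound 2 `CN1CCN(c2ccc(-c3cc4c(N5CCN(C(=O)Nc6ccc(Cl)cc6)CC5)ncnc4s3)cc2)CC1` gives 9270 nM

Of these two compounds, compound 2 holds the lower number, at 9270 nM, so it is the stronger inhibitor in this assay by a margin beyond the usual scatter. The next compound to be tested is compound 3 `CN1CCN(c2ccc(-c3cc4c(N5CCN(C(=O)Nc6ccc(OC(F)(F)F)cc6)CC5)ncnc4s3)cc2)CC1`, in which trifluoromethoxy stands in place of chloro on an aromatic carbon (trifluoromethoxy in place of chloro on an aromatic carbon). For the measured compounds named here, only one measured step bears on this change. It is the exchange of methoxy for chloro on that same aromatic carbon, which gave a 3.2-fold lower number from compound 1 to compound 2 (0.51 log units; beyond the scatter). Going by the values given here, that single step was modest, and no measurement yet shows how trifluoromethoxy behaves at this place. A change of similar or smaller size is therefore expected, with a slight lean towards a lower number and no step beyond the scatter as the likeliest outcome. The expected change is a 1.2-fold lower number from compound 2 to compound 3 (0.06 log units; within the scatter). For compound 3 the estimated value is 8000 nM, with an expected range from 3000 nM to 22000 nM.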

Compound 3, half-maximal inhibitory concentration: 6250 nM
The estimate for compound 3 lay 1.3-fold (0.11 log units) above the measured number, and the stated range covers the measured number.
By their numbers in this assay, from the lowest: compounds 3 and 2 (each within the scatter of the next); then compound 1.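

In this assay the exchange of one chlorine for the five heavy atoms of trifluoromethoxy, on an aromatic carbon para to a large group, gives a 1.5-fold lower number from compound 2 to compound 3 (0.17 log units; within the scatter) and so leaves compounds 2 and 3 indistinguishable. For the compounds shown here, the added size and the added hydrogen-bond acceptor therefore bring no separation here, which the single earlier step could not show. The comparison with the methoxy compound gives a 4.8-fold lower number from compound 1 to compound 3 (0.68 log units; beyond the scatter) and, together with the earlier step from methoxy to chloro, shows that two different groups at this place now stand clear of compound 1 while staying within the scatter of each other. Nothing among the data offered gives a reason for these differences.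

Going by these compounds, it remains open how a bare hydrogen, an amine, a nitrile or a carboxylic acid on this same carbon would compare with these three groups. On these data alone, it is also open whether the small gap between chloro and trifluoromethoxy would hold on a different core, as all three compounds share one core and differ only in this single group.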